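Furan for Phenyl on a Saturated Ring Carbon

A few compounds are considered here, and "the series" means these few. Any claim that something is new, unique, unknown or untested is made for them only; others in the source may bear on it.

Compound 1 `Nc1sc(-c2ccccc2)c(-c2ccc(Cl)cc2)c1C(=O)NC1CC1`: in a functional assay on A549 cells (Homo sapiens) for cytotoxicity, read by sulforhodamine B assay, with a stated time of 72 h (a lower number here means a stronger inhibitor, a higher number a weaker inhibitor), compound 1 gives 4300 nM.
Compound 2 `Nc1sc(-c2ccc(F)cc2)c(-c2ccc(Cl)cc2)c1C(=O)NC1CC1`: in this assay compound 2 gives 3000 nM.
Compound 3 `O=C1CC(c2ccccc2)c2c(sc(-c3ccc(Cl)cc3)c2-c2ccc(Cl)cc2)N1`: in this assay compound 3 gives 17200 nM.

Compound 3 stands at the highest number of the three, so it is the weakest inhibitor here; the gaps to compound 1 and to compound 2 both lie beyond the usual scatter of repeated measurements, with compound 1 the nearer of the two.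

Compound 4 `O=C1CC(c2ccco2)c2c(sc(-c3ccc(Cl)cc3)c2-c2ccc(Cl)cc2)N1` is built from compound 3 by a single change: furan-2-yl in place of phenyl on a saturated ring carbon.

Among the compounds with values here, only one step between measured compounds is available, a 1.4-fold lower number from compound 1 to compound 2 (0.16 log units; within the scatter). That step concerns a fluoro substituent on an aromatic ring and a different place in the molecule, so it says little about swapping a whole phenyl for a furan-2-yl on the saturated ring carbon. Within the data shown here, the two rings are both aromatic and of similar size, and nothing among the measured compounds points to a change in either direction beyond the scatter.

Compound 4 is therefore estimated at about 17000 nM, with a likely range from 6000 nM to 50000 nM. The expected step is a 1.0-fold lower number from compound 3 to compound 4 (0.01 log units; within the scatter), essentially no change beyond the scatter.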

Compound 4, half-maximal inhibitory concentration: 25400 nM
Estimate against measurement, compound 4: 1.5-fold (0.17 log units) below; the range from low to high includes it.
By their numbers in this assay, from the lowest: compounds 2 and 1 (each within the scatter of the next); then compounds 3 and 4 (each within the scatter of the next).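

In this assay the change to furan-2-yl in place of phenyl on the saturated ring carbon gives a 1.5-fold higher number from compound 3 to compound 4 (0.17 log units; within the scatter) and so stays within the scatter. Within the data shown here, this is the first reading at this position, since the only earlier step concerned a fluoro group on an aromatic carbon elsewhere, and it shows that this carbon accepts a five-membered aromatic ring with an oxygen as readily as a six-membered ring of carbon only, with no change that can be told apart from repeat-measurement noise. The hydrogen-bond acceptor that enters with the furan-2-yl therefore leaves no mark on this cell read-out, and no measurement at hand offers an explanation for why the two rings read alike.

Going by these compounds, both compounds carry an aromatic ring on this carbon, so it remains open whether a plain hydrogen, an amine, a carboxylic acid or a longer alkyl chain there would move the number beyond the scatter. Compound 3 and compound 4 also differ from compound 1 and compound 2 in more than one place, so the gap between these two pairs cannot be assigned to any single change.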